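This account rests on a few compounds, and the source may have more. Where it says the series, first, only, none or still open, it means among the compounds named here.

Working notes on the urea series in a functional assay on CRL2813 cells (Homo sapiens) for cytotoxicity, read by sulforhodamine B assay, with a stated time of 5 days; a higher number here means a weaker inhibitor, a lower number a stronger inhibitor. Compound 1 `COC(=O)c1ccc(NC(=O)N[C@H]2CC[C@H](Oc3ccc(F)cc3)CC2)cc1` gives 11600 nM. Compound 3 `COc1ccc(NC(=O)N[C@H]2CC[C@H](Oc3ccc(F)cc3)CC2)cc1` returns only a limit, > 20000 nM, which is the limit of > 20000 nM in this assay, at which 1 of the 3 values shown sits. Among the measured compounds shown here, the single step measured in one place, an at least 1.7-fold higher number from compound 1 to compound 3 (0.23 log units; that floor lies within the scatter), touches the aryl urea side only. Compound 2 `O=C(Nc1cccc(C(F)(F)F)c1)N[C@H]1CC[C@H](Oc2ccc(Cl)cc2)CC1` gives 2000 nM, the lowest of the two numbers given, separated from compound 1 by a gap beyond the scatter.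

Compound 4 `O=C(Nc1cccc(C(F)(F)F)c1)N[C@H]1CC[C@H](O)CC1` differs from compound 2 by hydrogen in place of 4-chlorophenyl on an oxygen on a saturated carbon. For the measured compounds named here, the aryl ether is the same in compounds 1, 2 and 3, so no measured step bears on this change. Removing the whole 4-chlorophenyl is expected to raise the number, by roughly a 7.0-fold higher number from compound 2 to compound 4 (0.85 log units; beyond the scatter). For compound 4 the estimate is 14000 nM, within 5000 nM to 40000 nM.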

Compound 4, half-maximal inhibitory concentration: > 20000 nM
Compound 4: no number, only a limit; the forecaster's own chance of this, stated with the estimate: 35%; at least 1.4-fold (0.15 log units) between middle value and limit.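

In this assay, among the compounds shown here, the 4-chlorophenoxy to hydroxy change gives the first measured step on the ether side of the series: an at least 10-fold higher number from compound 2 to compound 4 (1.00 log units; beyond the scatter). Compound 4 gives only a limit, > 20000 nM, so this step is a floor and its full size cannot be read. Compound 4 thus joins the compounds at the limit: the limit of > 20000 nM in this assay, at which 2 of the 4 values shown sit.

The compounds shown leave open whether a methyl group on that oxygen, or an amine in place of the 4-chlorophenoxy, would keep the number of compound 2.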